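Removing the isopropyl group: lipophilicity notes

A few compounds are considered here, and "the series" means these few. Any claim that something is new, unique, unknown or untested is made for them only; others in the source may bear on it.

Measured so far:
compound 1 `Cc1nc(N)c2[nH]c(=O)n(Cc3ccccc3)c2c1C`: 2.6
compound 2 `CC(C)c1cc2c([nH]c(=O)n2Cc2ccccc2)c(N)n1`: 3.1

In a physicochemical assay for lipophilicity, measured as octanol-water partition, at pH 7.4 (on this read-out lower numbers stand for lower lipophilicity and higher numbers for higher lipophilicity), compound 2 gives 3.1, the highest of the two numbers. Compound 1 gives 2.6 in this assay, lower than compound 2 by a margin beyond the scatter. Compound 3 `Nc1nccc2c1[nH]c(=O)n2Cc1ccccc1` has not yet been measured in this assay.

The change from compound 2 to compound 3 is hydrogen in place of isopropyl on an aromatic carbon. For the measured compounds named here, no pair of measured compounds differs in this way, so the size of the step has to be estimated rather than read off. Taking away the isopropyl, three heavy atoms, all carbon, with no donors or acceptors, is expected to lower the reading in this assay; the expected step from compound 2 to compound 3 is a number 1.30 log units lower from compound 2 to compound 3 (beyond the scatter), beyond the scatter. Compound 3 is therefore expected to give 1.8 in this assay, with a range from 1.3 to 2.3.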

Compound 3, distribution coefficient: 1.9
For compound 3 the middle estimate is 0.10 log units below the measured one; measured number inside the range.
By their numbers in this assay, from the lowest: compound 3; then compound 1; then compound 2.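

In this assay, for the compounds shown here, hydrogen in place of isopropyl on the aromatic carbon next to the ring nitrogen gives a number 1.20 log units lower from compound 2 to compound 3 (beyond the scatter) and this is the only step so far that can be read between compounds differing in one place. The reading at this position therefore depends strongly on the choice between these two groups, which compounds 1 and 2 could not show, as they differ in more than one place. Nothing at hand accounts for the size of this step.

From the compounds shown here alone, with only hydrogen and isopropyl compared here, it remains open where an ethyl group, a cyclopropyl group or an amine on this carbon would fall on this read-out. Also open, going by these compounds, is whether a step of this size would recur with a carboxylic acid in place of the benzyl group on the core.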